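The compounds below may be only part of what the source reports. "The series", "measured", "known", "first", "only" and "open" are said of these compounds alone.

Compounds measured in a functional assay, tested at 100 ug/mL; on this read-out higher numbers stand for a stronger effect at the one concentration tested and lower numbers for a weaker effect:

- Compound 1, `N#CC1=C(N)OC(c2c[nH]c3ccccc23)=C(C#N)C1c1ccc2ccccc2c1`: compound 1 is reported as "not active" (no number reported)
- Compound 2, `Cc1ccccc1C1C(C#N)=C(N)OC(c2c[nH]c3ccccc23)=C1C#N`: compound 2 gives 17.2%
- Compound 3, `Cc1ccc(C2C(C#N)=C(N)OC(c3c[nH]c4ccccc34)=C2C#N)cc1`: compound 3 gives 5.5%

Compound 1 stands apart from the other two in that no number is given for it in this assay; it is simply recorded as not active, so it cannot be placed on the same scale as compound 2 or compound 3. The unmeasured compound 4, `N#CC1=C(N)OC(c2c[nH]c3ccccc23)=C(C#N)C1c1cccc2ccccc12`, shares every atom with compound 1 but joins them differently: naphthalen-1-yl in place of naphthalen-2-yl on a saturated ring carbon.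

For the measured compounds named here, only one step among the measured compounds is known, a number 11.7 percentage points lower from compound 2 to compound 3 (beyond the scatter), which concerns a shift of a methyl group on a phenyl ring attached at the same saturated ring carbon. That step is modest and runs downward, but it involves a different ring and a different pattern of attachment, so it bears on the change from compound 1 to compound 4 only loosely, as a sign that where a ring is joined at this position can move the read-out. Going by the values given here, with compound 1 reported as not active and no directly comparable step available, compound 4 is expected to remain weak in this assay, with a real chance that it too is reported only as not active. The estimate for compound 4 is 10%, within 0% to 30%.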

Compound 4, a percentage reported as activity, at one concentration (the size of the read-out at that concentration, not a potency): 6.8%
Compound 4: the middle estimate sits 3.2 percentage points above what was measured; the measured number falls inside the stated range.
By their numbers in this assay, from the lowest: compounds 3 and 4 (each within the scatter of the next); then compound 2.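

In this assay compound 4 gives 6.8%, while compound 1 stands as "not active" (no number reported), so the exchange of naphthalen-2-yl for naphthalen-1-yl on the saturated ring carbon cannot be read as a step of any size, although the naphthalen-1-yl compound does carry a number. Set against the single-ring groups at the same carbon, naphthalen-1-yl is not told apart from 4-methylphenyl, with a number 1.3 percentage points higher from compound 3 to compound 4 (within the scatter), but it does fall short of 2-methylphenyl, with a number 10.4 percentage points lower from compound 2 to compound 4 (beyond the scatter), which leaves compound 2 as the only one of the numbered compounds set apart from the others on this read-out. No available evidence accounts for either of these steps.

All the compounds shown differ only in the group on the saturated ring carbon, so it remains open whether any other group there, such as 3-methylphenyl or a phenyl ring bearing an amine or a carboxylic acid, would rise above the reading of compound 2. As far as these compounds go, it is equally open how the read-out would respond to replacing the 1H-indol-3-yl group, the amino group or either cyano group on the shared core.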